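The source may report more compounds than this note shows. Statements on the series, on what has been measured and on what is new or still open speak of the compounds shown alone.

Measured compounds in an assay on cells (Hepatocyte) for inhibition of glucokinase regulatory protein (Mus musculus), with stated times of 20 min and 40 min; a higher number here means that more compound is needed for the effect, a lower number that less compound is needed:
- compound 1 `CC#C[C@H]1CN(S(=O)(=O)c2ccc(N)nc2)CCN1c1ccc(S(=O)(=NC)C(F)(F)F)cc1`, 2060 nM
- compound 2 `CC#CCC(O)(c1ccc(N2CCN(S(=O)(=O)c3ccc(N)nc3)C[C@@H]2C#CC)cc1)C(F)(F)F`, 137 nM
- compound 3 `CC#C[C@H]1CN(S(=O)(=O)c2ccc(N)nc2)CCN1c1ncc(C(O)(C(F)(F)F)C(F)(F)F)cn1`, 2200 nM

Going by the values given here, compound 2 stands lowest of the three numbers in this assay; its nearest neighbour is compound 1 and its furthest is compound 3, and both gaps are beyond the scatter, so compound 2 is the most potent compound measured so far.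

Compound 4 `CC#C[C@H]1CN(S(=O)(=O)c2ccc(N)nc2)CCN1c1ccc([C@](O)(CO)C(F)(F)F)cc1` keeps the core of compound 2 and alters only the substituent on the carbon ring: a group of 8 heavy atoms (3 carbon, 2 oxygen, 3 fluorine; no ring) in place of a group of 10 heavy atoms (6 carbon, 1 oxygen, 3 fluorine; no ring), on an aromatic carbon. The group that leaves carries the triple bond of compound 2; the group that enters, 1,2-dihydroxy-1-(trifluoromethyl)ethyl, brings a second hydroxyl and a defined stereocentre in its place.

Among the compounds with values here, only one measured step bears on this position: a 15-fold lower number from compound 1 to compound 2 (1.18 log units; beyond the scatter). Within the data shown here, that step shows that exchanging the group on this aromatic carbon can move the number substantially, yet neither it nor compound 3 involves the group entering in compound 4, so no direct precedent for its direction exists. With the triple-bond chain of compound 2 removed, a moderate rise in the number is expected, a 3.6-fold higher number from compound 2 to compound 4 (0.56 log units; beyond the scatter), with a wide range in either direction. Compound 4 is therefore estimated at 500 nM, between 150 nM and 2000 nM.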

Compound 4, half-maximal effective concentration: 98 nM
For compound 4 the middle estimate is 5.1-fold (0.71 log units) above the measured one; measured number below the stated range.
By their numbers in this assay, from the lowest: compounds 4 and 2 (each within the scatter of the next); then compounds 1 and 3 (each within the scatter of the next).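

In this assay, the triple-bond group of compound 2 can be exchanged for 1,2-dihydroxy-1-(trifluoromethyl)ethyl on this aromatic carbon with a 1.4-fold lower number from compound 2 to compound 4 (0.15 log units; within the scatter), so the two groups stand level at this position. The low number is therefore not tied to the triple bond: a smaller group without one, carrying 2 hydrogen-bond donors and 2 hydrogen-bond acceptors, reaches the same level. Replacing the group of compound 1 gives a 21-fold lower number from compound 1 to compound 4 (1.32 log units; beyond the scatter), a large step that sits alongside a 15-fold lower number from compound 1 to compound 2 (1.18 log units; beyond the scatter) and shows two quite different groups on this carbon both giving a far lower number than the group of compound 1.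

Nothing at hand gives a reason for these steps. Still open are the contribution of the second hydroxyl and of the defined stereocentre, the group being shown in one configuration only, and whether an amine or a carboxylic acid in place of the terminal hydroxyl would keep the number at this level.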